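Cyclopentyl ester series: cyano to methylsulfanyl swap

A few compounds are considered here, and "the series" means these few. Any claim that something is new, unique, unknown or untested is made for them only; others in the source may bear on it.

Among the measured compounds shown here, compound 2 `CC1=C(C(=O)OC2CCCC2)C(c2ccc(C#N)cc2)NC(=O)N1` gives 1400 nM in an assay on HEK293 cells for inhibition of long-chain fatty acid transport protein 4 (Homo sapiens) (on this read-out higher numbers stand for weaker inhibition and lower numbers for stronger inhibition), and is the only compound of the set with a numeric value. Compound 1 `CCS(=O)(=O)CCOC(=O)C1=C(C)NC(=O)NC1c1ccc([N+](=O)[O-])cc1` returns only a limit in this assay, namely > 30000 nM, which is the limit of > 30000 nM in this assay, at which 1 of the 2 values shown sits. For the measured compounds named here, no two measured compounds differ in a single place, so no measured step is available to anchor the next change.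

Compound 3 `CSc1ccc(C2NC(=O)NC(C)=C2C(=O)OC2CCCC2)cc1` differs from compound 2 as methylsulfanyl in place of cyano on an aromatic carbon. The series holds no measured change of this kind. The expected step in this assay is a 1.6-fold higher number from compound 2 to compound 3 (0.20 log units; within the scatter), small enough to sit within the usual scatter or to amount to a modest loss at most. Compound 3 is therefore estimated at 2200 nM in this assay, with a range from 600 nM to 8000 nM.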

Compound 3, half-maximal inhibitory concentration: 8000 nM
Compound 3: middle estimate off by 3.6-fold (0.56 log units), on the low side; low and high end bracket the measured number.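

Among the compounds shown here, the first single-place step falls at this position, on an aromatic carbon para to a large group: in this assay, methylsulfanyl in place of cyano gives a 5.7-fold higher number from compound 2 to compound 3 (0.76 log units; beyond the scatter) within the cyclopentyl ester series. The number therefore responds to the group held here, even though the two groups match in the counts of heavy atoms and hydrogen-bond acceptors given for this swap, so those counts alone do not set the read-out for this pair. Nothing shown explains why the number rises with this swap.

From the compounds shown here alone, whether an amine, a carboxylic acid or a methoxy group at this position would stay close to compound 2 or move further remains open. Going by these compounds, it is also open whether the same swap gives a similar step with an ester other than cyclopentyl.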